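A few compounds are considered here, and "the series" means these few. Any claim that something is new, unique, unknown or untested is made for them only; others in the source may bear on it.

Measured compounds:
compound 1, `Cc1nc(-c2ccsc2)sc1COc1ccc2c(c1)OCC2CC(=O)O`, 56.5% in a functional assay on CHO cells for agonist activity at Free fatty acid receptor 1 (Homo sapiens), read by FLIPR and calcium flux, tested at 100 nM; a lower number here means a weaker effect, a higher number a stronger effect of the compound at the concentration tested;
compound 2, `Cc1nc(-c2cccc3ccccc23)sc1COc1ccc2c(c1)OCC2CC(=O)O`, 8.53% in this assay;
compound 3, `Cc1nc(-c2ccccc2C(F)(F)F)sc1COc1ccc2c(c1)OCC2CC(=O)O`, 7.76% in this assay.

Compound 3 stands lowest of the three numbers; compound 2 sits nearest, differing only within the scatter, while compound 1 sits far higher. Compound 4 is `COc1cc(OC)cc(-c2nc(C)c(COc3ccc4c(c3)OCC4CC(=O)O)s2)c1`. It differs from compound 3 by 3,5-dimethoxyphenyl in place of 2-(trifluoromethyl)phenyl on an aromatic carbon. For the measured compounds named here, the steps that bear on this change are a number 48.7 percentage points lower from compound 1 to compound 3 (beyond the scatter) and a number 0.8 percentage points lower from compound 2 to compound 3 (within the scatter). Going by the values given here, no measured step swaps in a 3,5-dimethoxyphenyl, so the direction is uncertain; a modest rise is expected, a number 17.2 percentage points higher from compound 3 to compound 4 (beyond the scatter), with wide bounds. Compound 4 is therefore estimated at 25%, expected between 3% and 60%.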

Compound 4, a percentage reported as activity, at one concentration (the size of the read-out at that concentration, not a potency): 17.5%
Beside the measured number, compound 4's estimate is 7.5 percentage points above it; low and high end bracket the measured number.
By their numbers in this assay, from the lowest: compounds 3, 2 and 4 (each within the scatter of the next); then compound 1.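

In this assay, 3,5-dimethoxyphenyl on this carbon of the ring gives a number 9.7 percentage points higher from compound 3 to compound 4 (within the scatter) and a number 9 percentage points higher from compound 2 to compound 4 (within the scatter), so it cannot be told apart from either earlier replacement, even though it brings hydrogen-bond acceptors that 2-(trifluoromethyl)phenyl lacks. Thiophen-3-yl remains clearly ahead, with a number 39 percentage points lower from compound 1 to compound 4 (beyond the scatter), making this the third replacement to fall well short of it.

Nothing here explains why thiophen-3-yl stands apart. Going by these compounds, whether a furan-3-yl or pyridin-3-yl group at this position would match thiophen-3-yl remains open.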